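The source may hold more compounds than are shown below. What is called first, only, known or untested is meant among the compounds shown, and "the series" means these compounds.

Measured so far:
compound 1 `NC(=O)c1ccccc1NC(=O)COc1ccccc1`: 57.4%
compound 2 `NC(=O)c1cc(Cl)ccc1NC(=O)COc1ccccc1`: 87%

In a functional assay on K562 cells (Homo sapiens) for inhibition, read by trypan blue exclusion, with a stated time of 24 h, tested at 10 uM (a higher number here means more inhibition of growth at the concentration tested, a lower number less inhibition of growth), compound 2 stands highest of the two, at 87%, and compound 1 lies lower, at 57.4%. The next compound is compound 3 `NC(=O)c1cc(I)ccc1NC(=O)COc1ccccc1`, with iodo in place of chloro on an aromatic carbon, meta to a carbamoyl group and para to a large group: iodo in place of chloro on an aromatic carbon.

Among the measured compounds shown here, one measured step bears on this change: a number 29.6 percentage points higher from compound 1 to compound 2 (beyond the scatter), with chloro in place of hydrogen on the same aromatic carbon. That step compares a halogen with hydrogen. For the measured compounds named here, no measured compound shows what one halogen does in place of another, and no iodo compound has been measured. The expectation therefore stays close to compound 2 at 87%, with little room left above it on this read-out. The expected change is small and probably downward, within the scatter: a number 4 percentage points lower from compound 2 to compound 3 (within the scatter). Compound 3 is estimated at 83%, with an expected range of 65% to 97%.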

Compound 3, percent growth inhibition at one concentration: 73%
Estimate against measurement, compound 3: 10 percentage points above; the range from low to high includes it.
By their numbers in this assay, from the lowest: compound 1; then compound 3; then compound 2.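

At the aromatic carbon meta to the carbamoyl group and para to the large group, the choice of halogen matters in this assay: exchanging chloro for iodo gives a number 14 percentage points lower from compound 2 to compound 3 (beyond the scatter) and shows that the two halogens are not interchangeable here. Iodo in place of hydrogen still gives a number 15.6 percentage points higher from compound 1 to compound 3 (beyond the scatter) and so keeps part of the gain, which places both halogens shown above hydrogen at this carbon, with chloro above iodo. Nothing available accounts for this difference between chloro and iodo.

Open, from the compounds shown here alone, is how bromo or fluoro would stand against chloro and iodo at this carbon, and whether a methoxy group or an amine there would also exceed hydrogen. Also open, going by these compounds, is whether chloro stays above iodo at another carbon of the same ring.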